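Replacing a chlorobenzyl amine with a dimethylmorpholine ring

A few compounds are considered here, and "the series" means these few. Any claim that something is new, unique, unknown or untested is made for them only; others in the source may bear on it.

Of the compounds shown here, two have been measured so far. Compound 1 `Cc1csc2cc([C@H](C)Nc3ncnc(N)c3C#N)c(-c3cccc(CN4CCC(CN(C)Cc5ccccn5)CC4)c3)c(=O)n12` and compound 2 `Cc1csc2cc([C@H](C)Nc3ncnc(N)c3C#N)c(-c3cccc(CN(C)CCCN(C)Cc4ccc(Cl)cc4)c3)c(=O)n12` share one core and differ only in the side chain that hangs from the aromatic ring. In an ADME assay on the whole organism (lung, Rattus norvegicus) for metabolic stability, read by LC-MS (a lower number here means that the compound disappears faster, a higher number that the compound lasts longer), compound 1 gives 10.9 h, and in this assay compound 2 gives 13 h; the two numbers lie within the usual scatter of each other, so neither can be said to outlast the other. Compound 3 `Cc1csc2cc([C@H](C)Nc3ncnc(N)c3C#N)c(-c3cccc(CN(C)CCCCN4C[C@@H](C)O[C@@H](C)C4)c3)c(=O)n12` keeps the core of compound 2 and changes the side chain: (2,6-dimethylmorpholin-4-yl)methyl in place of (4-chlorobenzyl)(methyl)amino on a saturated chain carbon, three bonds along the chain from an amine nitrogen. Among the measured compounds shown here, no measured pair shows a change of this kind, so nothing in the numbers points one way or the other, and the step from compound 2 to compound 3 in this assay is expected to stay within the scatter, at a 1.1-fold lower number from compound 2 to compound 3 (0.03 log units; within the scatter). Compound 3 is therefore estimated to give 12 h in this assay, with a likely range from 5 h to 26 h.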

Compound 3, half-life: 7.6 h
For compound 3 the middle estimate is 1.6-fold (0.20 log units) above the measured one; measured number inside the range.
By their numbers in this assay, from the lowest: compounds 3, 1 and 2 (each within the scatter of the next).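

Moving the side chain of compound 2 to that of compound 3, with (2,6-dimethylmorpholin-4-yl)methyl in place of (4-chlorobenzyl)(methyl)amino, gives a 1.7-fold lower number from compound 2 to compound 3 (0.23 log units; within the scatter) in this assay and is the first change in this series that can be read at a single place. At this place, on a saturated chain carbon, three bonds along the chain from an amine nitrogen, a carbon-only aromatic ring bearing chlorine and a non-aromatic ring holding oxygen therefore cannot be told apart in this measurement. Nothing measured here offers an explanation for this result.

From the compounds shown here alone, whether a plain morpholine without the two methyl groups would also stay within the scatter of compound 2 remains open. The same question stands for a carboxylic acid at this place.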